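Swapping the halogenated phenyl on the thioether sulfur

This account rests on a few compounds, and the source may have more. Where it says the series, first, only, none or still open, it means among the compounds named here.

Compound 1, `Cc1ccc(CSc2ncnc3c2ncn3[C@@H]2O[C@H](CO)[C@@H](O)[C@H]2O)cc1`: 457 nM
Compound 2, `OC[C@H]1O[C@@H](n2cnc3c(CSc4ccc(Cl)c(Cl)c4)ncnc32)[C@H](O)[C@@H]1O`: 224 nM

In an assay on isolated protein for binding affinity to Equilibrative nucleoside transporter 1 (Homo sapiens) (on this read-out higher numbers stand for weaker inhibition and lower numbers for stronger inhibition), compound 2 gives the lowest number of the two shown; compound 1 gives a higher number, a gap beyond the usual scatter. Compound 3, `OC[C@H]1O[C@@H](n2cnc3c(CSc4ccc(Br)cc4)ncnc32)[C@H](O)[C@@H]1O`, is the next step: 4-bromophenyl in place of 3,4-dichlorophenyl on a sulfur. Among the compounds with values here, no measured pair covers this exact change, so the expectation rests on the two numbers above alone. The step from compound 2 to compound 3 is expected to be small, toward a slightly higher number, possibly not beyond the scatter, as a 1.6-fold higher number from compound 2 to compound 3 (0.19 log units; within the scatter). Compound 3 is therefore estimated at 350 nM, within a range from 150 nM to 900 nM.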

Compound 3, half-maximal inhibitory concentration: 178 nM
Estimate against measurement, compound 3: 2.0-fold (0.29 log units) above; the range from low to high includes it.
By their numbers in this assay, from the lowest: compounds 3 and 2 (each within the scatter of the next); then compound 1.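

In this assay, the step of a 1.3-fold lower number from compound 2 to compound 3 (0.10 log units; within the scatter) stays within the usual scatter, so on this sulfur 4-bromophenyl and 3,4-dichlorophenyl cannot be told apart. The step of a 2.6-fold lower number from compound 1 to compound 3 (0.41 log units; beyond the scatter) lies beyond the scatter and is modest, so ((4-bromophenyl)sulfanyl)methyl on the aromatic carbon gives a clearly lower number than (4-methylbenzyl)sulfanyl there. Still open, on these data alone, is whether a group without the phenyl ring, such as an amine or a carboxylic acid, would hold this level on the sulfur. Nothing shown speaks to why these steps come out as they do.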